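One More Methoxy at the Limit of Tolerance

The compounds below may be only part of what the source reports. "The series", "measured", "known", "first", "only" and "open" are said of these compounds alone.

In an ADME assay on MDBK cells (Bos taurus) for cytotoxicity, read by MTT assay, with a stated time of 96 h (a lower number here means that less compound is tolerated, a higher number that more compound is tolerated), compound 3 `COc1ccc(-c2nc3cc(C(C)O)ccc3[nH]2)c(OC)c1` gives > 100000 nM as a limit of the assay and not as a number. Compound 2 `COc1ccc(-c2nc3cc(C(C)O)ccc3[nH]2)cc1` likewise gives > 100000 nM as a limit. Among the measured compounds shown here, the only measured methoxy step is a step that the two limits leave unreadable from compound 2 to compound 3 and it offers no size to carry forward. Compound 4 `COc1ccc(-c2nc3cc(C(C)O)ccc3[nH]2)c(OC)c1OC` differs from compound 3 by methoxy in place of hydrogen on an aromatic carbon and so adds methoxy in place of hydrogen on an aromatic carbon, ortho to two methoxy groups. The same methoxy groups stand on compound 1 `COc1ccc(-c2nc3cc(C(C)=O)ccc3[nH]2)c(OC)c1OC` in a structure with a carbonyl in its side chain. Compound 1 gives > 100000 nM as a limit too. For the measured compounds named here, the measured compounds all rest on the limit of > 100000 nM in this assay, at which 3 of the 3 values shown sit, and no measured step in this assay shows a change, so no step beyond the scatter is expected. The expected step is a number no higher from compound 3 to compound 4 (the limit leaves the size open) and no larger one is foreseen. For compound 4 the estimate is 100000 nM with an expected range from 60000 nM to 200000 nM and a report as a limit once more is the likeliest outcome.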

Compound 4, half-maximal cytotoxic concentration: 60000 nM
Beside the measured number, compound 4's estimate is 1.7-fold (0.22 log units) above it; the range from low to high includes it.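

In this assay, among the compounds shown here, the methoxy ortho to two methoxy groups gives the first methoxy step with a readable floor, an at least 1.6-fold lower number from compound 3 to compound 4 (0.22 log units; that floor lies within the scatter). 1-Hydroxyethyl in place of acetyl on an aromatic carbon gives an at least 1.6-fold lower number from compound 1 to compound 4 (0.22 log units; that floor lies within the scatter), so the side chain now carries the same floor, and neither step can yet be told apart from scatter. Compound 4 alone reads as a number, while the other compounds stay at a limit of the assay: the limit of > 100000 nM in this assay, at which 3 of the 4 values shown sit.

On these data alone, the true size of both steps stays open, and so does whether either change matters at all in this assay. The compounds shown also do not tell how an amine or a carboxylic acid in place of the 1-hydroxyethyl, or a longer chain in place of this methoxy, would read.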